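A fluorinated carboxyphenyl replaces the methyl-bearing one

A few compounds are considered here, and "the series" means these few. Any claim that something is new, unique, unknown or untested is made for them only; others in the source may bear on it.

Compound 3 `Cc1cc(OCCCCOc2ccc(C(=O)CC3CCCC3)c(O)c2C)ccc1C(=O)O` carries a 4-carboxy-3-methylphenyl on an oxygen on a saturated carbon. In an assay on HEK293 cells for positive allosteric modulation of metabotropic glutamate receptor 3 (Rattus norvegicus), read by thallium flux, with a stated time of 2.5 min (on this read-out lower numbers stand for an effect already at smaller amounts and higher numbers for an effect only at larger amounts of compound), compound 3 gives only a limit, > 10000 nM. Compound 1 `Cc1c(OCCCCOc2ccc(C(=O)O)cc2Cl)ccc(C(=O)CC2CCCC2)c1O`, with a 4-carboxy-2-chlorophenyl, likewise gives only a limit in this assay, > 10000 nM. Compound 2 `Cc1c(OCCCCOc2ccc(F)c(C(=O)O)c2)ccc(C(=O)CC2CCCC2)c1O`, with a 3-carboxy-4-fluorophenyl, gives a number in this assay, 2490 nM. The two limits leave a step that the two limits leave unreadable from compound 1 to compound 3 unreadable, while an at least 4.0-fold lower number from compound 1 to compound 2 (0.60 log units; beyond the scatter) and an at least 4.0-fold higher number from compound 2 to compound 3 (0.60 log units; beyond the scatter) show that both compound 1 and compound 3 sit at the limit of > 10000 nM in this assay, at which 2 of the 3 values shown sit. Compound 4 `Cc1c(OCCCCOc2ccc(C(=O)O)cc2F)ccc(C(=O)CC2CCCC2)c1O` differs from compound 3 by 4-carboxy-2-fluorophenyl in place of 4-carboxy-3-methylphenyl on an oxygen on a saturated carbon. Compound 1 is the closest measured comparison, and it too gives only a limit, > 10000 nM. The expected step is therefore an at least 1.2-fold lower number from compound 3 to compound 4 (0.09 log units; that floor lies within the scatter). Compound 4 is estimated at 8000 nM, between 2500 nM and 30000 nM.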

Compound 4, half-maximal effective concentration: > 10000 nM
Compound 4 was reported as a limit (the forecaster's own chance of this, stated with the estimate: 60%); middle value at least 1.2-fold (0.09 log units) from the limit.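

Fluoro in place of chloro on an aromatic carbon yields no number: compound 4 gives only a limit in this assay, > 10000 nM. A fluorine alone therefore does not set the result, since 3-carboxy-4-fluorophenyl and 4-carboxy-2-fluorophenyl carry the same substituents and still show an at least 4.0-fold higher number from compound 2 to compound 4 (0.60 log units; beyond the scatter). The steps among the compounds at the limit cannot be read, and that limit now holds most of the set: the limit of > 10000 nM in this assay, at which 3 of the 4 values shown sit.

On these data alone, whether a 3-carboxy-4-chlorophenyl or an unsubstituted 3-carboxyphenyl would give a number stays open. So does the effect of an amide in place of the carboxylic acid.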